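Aryl ether swap on a shared core: cytotoxicity notes

A few compounds are considered here, and "the series" means these few. Any claim that something is new, unique, unknown or untested is made for them only; others in the source may bear on it.

Measured so far in a functional assay on HL-60 cells (Homo sapiens) for cytotoxicity, read by WST assay, with a stated time of 48 h; on this read-out higher numbers stand for an effect only at larger amounts of compound and lower numbers for an effect already at smaller amounts:
compound 1, `O=C1OC[C@H](Cc2ccccc2)[C@H]1Cc1ccccc1OC(F)(F)F`, 39000 nM
compound 2, `COCOc1ccccc1C[C@H]1C(=O)OC[C@@H]1Cc1ccccc1`, 76000 nM
compound 3, `O=C1OC[C@H](Cc2ccccc2)[C@H]1Cc1cccc(OC(F)(F)F)c1`, 34000 nM

Compound 1 and compound 2 differ by methoxymethyl in place of trifluoromethyl on an oxygen on an aromatic ring, and in this assay this gives a 1.9-fold higher number from compound 1 to compound 2 (0.29 log units; within the scatter). Compound 3 carries the same side group as compound 1, but the difference between the two cores is not broken down here; their two numbers in this assay lie within the scatter of each other. Compound 4, `COCOc1cccc(C[C@H]2C(=O)OC[C@@H]2Cc2ccccc2)c1`, is not yet measured. It differs from compound 3 by methoxymethyl in place of trifluoromethyl on an oxygen on an aromatic ring, the same change as from compound 1 to compound 2, at a place described in the same words. The expected step is therefore a 1.9-fold higher number from compound 3 to compound 4 (0.28 log units; within the scatter) in this assay, resting on a 1.9-fold higher number from compound 1 to compound 2 (0.29 log units; within the scatter). For compound 4 the estimate in this assay is 65000 nM, with a likely range from 30000 nM to 140000 nM.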

Compound 4, half-maximal effective concentration: 80000 nM
For compound 4 the middle estimate is 1.2-fold (0.09 log units) below the measured one; the range from low to high includes it.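

In this assay the change from trifluoromethoxy to methoxymethoxy gives a 2.4-fold higher number from compound 3 to compound 4 (0.37 log units; beyond the scatter), and the step on the core of compound 1 points the same way at a size that cannot be told apart from it: the same change on two cores in this assay, a 1.9-fold higher number (0.29 log units; within the scatter) from compound 1 to compound 2 and a 2.4-fold higher number (0.37 log units; beyond the scatter) from compound 3 to compound 4, 1.2-fold (0.08 log units) apart, within the scatter of two such steps. Across these two pairs, then, the change carries from one core to the other, even though only the step on the core of compound 3 lies beyond the scatter. Two pairs say nothing about further cores and give no reason for the step.

Still open, going by these compounds, is what a free hydroxyl, an amine, a carboxylic acid or a longer chain would do in place of these groups. Also open, on these data alone, is whether a change on the other aromatic ring would shift the numbers.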